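Swapping Isopropyl for Iodo: What Compound 4 Might Show

The compounds below may be only part of what the source reports. "The series", "measured", "known", "first", "only" and "open" are said of these compounds alone.

Of the compounds shown here, three have so far been measured in a functional assay on HT-29 cells (Homo sapiens) for antiproliferative activity, read by sulforhodamine B assay, with a stated time of 48 h; a higher number here means a weaker inhibitor, a lower number a stronger inhibitor. Compound 1 `O=C(CCCl)Nc1ccc(S(=O)(=O)Oc2ccccc2I)cc1` gives 14000 nM, compound 2 `CCNC(=O)Nc1ccc(S(=O)(=O)Oc2ccccc2I)cc1` gives 5300 nM, and compound 3 `CC(C)c1ccccc1OS(=O)(=O)c1ccc(NC(=O)NCCCCl)cc1` gives 6900 nM, the second highest of the three numbers, within the scatter of compound 2 and separated only from compound 1 beyond it. Within the data shown here, the one single-point step measured, a 2.6-fold lower number from compound 1 to compound 2 (0.42 log units; beyond the scatter), concerns the carbonyl substituent and does not touch the change now considered. Compound 4 `O=C(NCCCCl)Nc1ccc(S(=O)(=O)Oc2ccccc2I)cc1` differs from compound 3 by iodo in place of isopropyl on an aromatic carbon. Among the measured compounds shown here, compounds 1 and 2 already carry the iodo of compound 4, yet no measured pair isolates this swap. With nothing bearing on it, the estimated step is a 1.1-fold lower number from compound 3 to compound 4 (0.03 log units; within the scatter), within the scatter. Compound 4 is therefore expected to give 6500 nM, ranging from 2500 nM to 16000 nM.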

Compound 4, half-maximal inhibitory concentration: 9600 nM
Beside the measured number, compound 4's estimate is 1.5-fold (0.17 log units) below it; the range from low to high includes it.
By their numbers in this assay, from the lowest: compounds 2, 3, 4 and 1 (each within the scatter of the next, the first and the last beyond it).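

In this assay, iodo in place of isopropyl on an aromatic carbon, ortho to a large group, can now be read directly: a 1.4-fold higher number from compound 3 to compound 4 (0.14 log units; within the scatter), so this change stays within the scatter. With iodo held fixed, the carbonyl-side steps, a 1.8-fold higher number from compound 2 to compound 4 (0.26 log units; within the scatter) and a 1.5-fold lower number from compound 1 to compound 4 (0.16 log units; within the scatter), also stay within it, although the step of a 2.6-fold lower number from compound 1 to compound 2 (0.42 log units; beyond the scatter) lies beyond it. Nothing available accounts for these numbers. Still open, going by these compounds, is whether an amine, a carboxylic acid or a methoxy group on this aromatic carbon would shift the value beyond the scatter. On these data alone, whether the swap gives the same result alongside the ethylamino or 2-chloroethyl carbonyl substituents is also open.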